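Moving the methyl on the benzyloxy arm: compound 3 expected

This account rests on a few compounds, and the source may have more. Where it says the series, first, only, none or still open, it means among the compounds named here.

Among the measured compounds shown here, the two compounds measured so far share one core and differ only at the benzyloxy arm. Compound 1 `COc1cccc(OC)c1OCCNCCOc1ccccc1OCc1ccccc1` gives 0.468 nM in an assay on CHO cells for displacement of a labelled ligand from Alpha-1A adrenergic receptor (Homo sapiens); on this read-out lower numbers stand for stronger inhibition and higher numbers for weaker inhibition. Compound 2 `COc1cccc(OC)c1OCCNCCOc1ccccc1OCc1ccccc1C` carries a methyl in place of hydrogen on an aromatic carbon of that arm and gives 1.59 nM in this assay; this is the highest of the two numbers, and the step of a 3.4-fold higher number from compound 1 to compound 2 (0.53 log units; beyond the scatter) lies beyond the scatter. Compound 3 `COc1cccc(OC)c1OCCNCCOc1ccccc1OCc1cccc(C)c1` has the same atoms joined differently: 3-methylphenyl in place of 2-methylphenyl on a saturated chain carbon bound to an oxygen on an aromatic ring. For the measured compounds named here, no measured step covers a move of the methyl from one aromatic carbon to another, so the only bearing comes from the step of a 3.4-fold higher number from compound 1 to compound 2 (0.53 log units; beyond the scatter), which shows that a methyl on this arm can shift the number by a modest amount. Its new position may keep or partly release that shift. Compound 3 is therefore expected to fall between compound 1 and compound 2, a step of a 1.6-fold lower number from compound 2 to compound 3 (0.20 log units; within the scatter) that may well remain within the scatter. The estimate for compound 3 is 1 nM, in the range 0.35 nM to 3 nM.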

Compound 3, inhibition constant: 0.398 nM
Compound 3: middle estimate off by 2.5-fold (0.40 log units), on the high side; the measured number falls inside the stated range.
By their numbers in this assay, from the lowest: compounds 3 and 1 (each within the scatter of the next); then compound 2.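

In this assay, the place of the methyl on the benzyloxy arm matters: a 4.0-fold lower number from compound 2 to compound 3 (0.60 log units; beyond the scatter), so the same atoms joined differently, 3-methylphenyl in place of 2-methylphenyl, give a step beyond the scatter. The earlier step could have been read as the effect of any methyl on this arm, but the 3-methylphenyl arm cannot be told apart from the arm without a methyl: a 1.2-fold lower number from compound 1 to compound 3 (0.07 log units; within the scatter). Among these three compounds, then, only the 2-methylphenyl arm stands apart from the others, and nothing available gives a reason for the difference between the two placements.

What the compounds shown leave open is whether the 3-methylphenyl result extends beyond methyl, for instance to a methoxy group, a chlorine atom or a nitrile at that same place on the arm, or to a longer chain such as ethyl. They also leave open whether the step between the 2-methylbenzyl and 3-methylbenzyl arms would appear on a different core, since all three compounds share one.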